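The source may report more compounds than this note shows. Statements on the series, on what has been measured and on what is new or still open speak of the compounds shown alone.

Working notes on the series, read in a functional assay on PC-3 cells (Homo sapiens) for cytotoxicity, read by MTT assay, with a stated time of 72 h; a lower number here means a stronger inhibitor, a higher number a weaker inhibitor. Within the data shown here, compound 3 `CNC(=O)c1cc(Oc2ccc(NC(=O)c3cc(-c4ccccc4)ncn3)cc2)ccn1` gives 44200 nM, the only true number so far. Compound 1 `CNC(=O)c1cc(Oc2ccc(NC(=O)c3cc(-c4ccc(C(F)(F)F)cc4)ncn3)cc2F)ccn1` gives > 100000 nM, which is a limit of the assay and not a number. Compound 2 `CNC(=O)c1cc(Oc2ccc(NC(=O)c3cc(-c4ccc(Br)cc4)ncn3)cc2F)ccn1` gives > 100000 nM, again a limit and not a number. The picture so far is therefore one number plus (the limit of > 100000 nM in this assay, at which 2 of the 3 values shown sit).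

Compound 4 `CNC(=O)c1cc(Oc2ccc(NC(=O)c3cc(-c4ccccc4)ncn3)cc2F)ccn1` differs from compound 3 by a single change: fluoro in place of hydrogen on an aromatic carbon. Among the measured compounds shown here, the only measured step, a step that the two limits leave unreadable from compound 1 to compound 2, concerns another place and offers no size to carry over, so no measured step isolates this change. Compound 1 and compound 2 both carry this fluoro, but each also carries a further group, trifluoromethyl or bromo, so neither shows the effect of the fluoro alone. Compound 2, at the limit of > 100000 nM, tilts the expectation slightly towards the weaker side without fixing a size. The expected change is small and probably not beyond the scatter: a 1.4-fold higher number from compound 3 to compound 4 (0.13 log units; within the scatter). Compound 4 is estimated at 60000 nM, with an expected range from 25000 nM to 100000 nM.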

Compound 4, half-maximal inhibitory concentration: 44300 nM
The estimate for compound 4 lay 1.4-fold (0.13 log units) above the measured number, and the stated range covers the measured number.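

In this assay, among these compounds, the fluoro ortho to a (2-(methylcarbamoyl)pyridin-4-yl)oxy group is seen alone for the first time: the change gives a 1.0-fold higher number from compound 3 to compound 4 (0.00 log units; within the scatter) and so leaves no shift that can be told from repeat scatter. With that fluoro kept in place, hydrogen in place of bromo gives an at least 2.2-fold lower number from compound 2 to compound 4 (0.35 log units; beyond the scatter) and hydrogen in place of trifluoromethyl gives an at least 2.2-fold lower number from compound 1 to compound 4 (0.35 log units; beyond the scatter) so among these compounds the shift beyond the scatter goes with the further group and not with the fluoro. Both of these steps give only a minimum size, because compound 1 and compound 2 each sit at a limit of the assay and not at a number: the limit of > 100000 nM in this assay, at which 2 of the 4 values shown sit.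

Going by these compounds, the step between compound 1 and compound 2 cannot be read, so the order of bromo and trifluoromethyl stays unknown, as does the true size of their steps to compound 4. Also open, on these data alone, is whether chloro or methoxy at the place of the fluoro would move the number, and whether methyl or methoxy at the place of the bromo would give a true number rather than a limit.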